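The source may hold more compounds than are shown below. What is called first, only, known or untested is meant among the compounds shown, and "the series" means these compounds.

Measured in a physicochemical assay for lipophilicity, read by HPLC, measured as chromatographic lipophilicity, at pH 7.4; on this read-out higher numbers stand for higher lipophilicity and lower numbers for lower lipophilicity:
Compound 1 `O=C(C1CCCC1)N1N=CCC1c1ccccc1`: 5.4
Compound 2 `O=C(C1CCOC1)N1N=CCC1c1ccccc1`: 3

Of these two, compound 2 stands lower, at 3 in this assay. Compound 3 `CC(C)C(=O)N1N=CCC1c1ccccc1` keeps the shared core and carries isopropyl in place of oxolan-3-yl on a carbonyl carbon. Going by the values given here, only one measured step bears on this change: a number 2.40 log units lower from compound 1 to compound 2 (beyond the scatter). That step is large and beyond the scatter, and it brought in the same oxolan-3-yl, there in place of cyclopentyl. Taking oxolan-3-yl out again should therefore move the number upward. Isopropyl is not cyclopentyl, however, and no measured compound carries it, so a full return is not expected. The expected move is a number 1.40 log units higher from compound 2 to compound 3 (beyond the scatter), beyond the scatter yet smaller than the measured step. For compound 3 the estimate is 4.4, with an expected range from 3.8 to 5.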

Compound 3, distribution coefficient: 4.4
For compound 3 middle estimate and measured number coincide at the digits printed; low and high end bracket the measured number.
By their numbers in this assay, from the lowest: compound 2; then compound 3; then compound 1.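

In this assay, isopropyl in place of oxolan-3-yl on the carbonyl carbon gives a number 1.40 log units higher from compound 2 to compound 3 (beyond the scatter), whereas isopropyl in place of cyclopentyl gives a number 1.00 log units lower from compound 1 to compound 3 (beyond the scatter). This position therefore separates even two groups without a hetero atom, and across these three compounds the hydrogen-bond acceptor count of the group does not alone set the number. Nothing available here explains these differences.

As far as these compounds go, the change from oxolan-3-yl to isopropyl removes the ring and the hetero atom together, and the shares of the two remain open. Also open, from the compounds shown here alone, is how this read-out would respond to an amine, a carboxylic acid or a longer chain on the same carbonyl carbon.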